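Replacing piperidin-1-yl with an open-chain diamine

A few compounds are considered here, and "the series" means these few. Any claim that something is new, unique, unknown or untested is made for them only; others in the source may bear on it.

In a functional assay on PC-3 cells (Homo sapiens) for antiproliferative activity, with a stated time of 72 h (on this read-out higher numbers stand for weaker inhibition and lower numbers for stronger inhibition), compound 2 `COc1cc(OC)c(C(=O)/C=C/c2ccccc2Cl)c(O)c1CN1CCCCC1` gives the lowest number of the three measured compounds at 1700 nM, against compound 3 `CCN(CC)Cc1c(OC)cc(OC)c(C(=O)/C=C/c2ccccc2Cl)c1O` at 4200 nM and compound 1 `COC(=O)CN(C)Cc1c(OC)cc(OC)c(C(=O)/C=C/c2ccccc2Cl)c1O` at 7200 nM. Compound 4 `COc1cc(OC)c(C(=O)/C=C/c2ccccc2Cl)c(O)c1CN(C)CCCN(C)C` differs from compound 2 by (3-(dimethylamino)propyl)(methyl)amino in place of piperidin-1-yl on a saturated chain carbon bound to an aromatic carbon, with (3-(dimethylamino)propyl)(methyl)amino in place of piperidin-1-yl on a saturated chain carbon bound to an aromatic carbon. Two measured steps away from piperidin-1-yl bear on this: a 2.5-fold higher number from compound 2 to compound 3 (0.39 log units; beyond the scatter) and, read in reverse, a 4.2-fold lower number from compound 1 to compound 2 (0.63 log units; beyond the scatter). The two open-chain compounds remain close, with a 1.7-fold lower number from compound 1 to compound 3 (0.23 log units; within the scatter). A modest step to a higher number is therefore expected in this assay, estimated as a 1.8-fold higher number from compound 2 to compound 4 (0.25 log units; within the scatter). Compound 4 is estimated at 3000 nM, with an expected range of 1100 nM to 8000 nM.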

Compound 4, half-maximal inhibitory concentration: 14500 nM
Estimate against measurement, compound 4: 4.8-fold (0.68 log units) below; measured number above the stated range.
By their numbers in this assay, from the lowest: compound 2; then compounds 3, 1 and 4 (each within the scatter of the next, the first and the last beyond it).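

In this assay, (3-(dimethylamino)propyl)(methyl)amino moves the number much further from that of piperidin-1-yl than diethylamino did (an 8.5-fold higher number from compound 2 to compound 4 (0.93 log units; beyond the scatter)) and also sits clearly apart from diethylamino (a 3.5-fold higher number from compound 3 to compound 4 (0.54 log units; beyond the scatter)). The open-chain compound with the second amine nitrogen is not separated from the ester-bearing chain (a 2.0-fold higher number from compound 1 to compound 4 (0.30 log units; within the scatter)). Nothing available accounts for the size of these steps. Still open, going by these compounds, is whether the ring or the second amine nitrogen matters more. A pyrrolidine or morpholine on this carbon, or a shorter chain ending in dimethylamino, would bear on that.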